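Removing a Triazole Methyl Group: What the Data Allow

The source may report more compounds than this note shows. Statements on the series, on what has been measured and on what is new or still open speak of the compounds shown alone.

Measured so far:
Compound 1 `Cn1c(Cc2nn(C)c(=O)c3ccccc23)nnc1SCCCCCCCC(=O)Nc1ccc(Cl)cc1Cl` gives 3900 nM.
Compound 2 `Cn1nc(Cc2nnc(SCC(=O)Nc3ccc(Cl)cc3Cl)n2CCC=O)c2ccccc2c1=O` gives 6400 nM.

Both compounds were tested in an assay on 32D cells for inhibition of interleukin-15 (Mus musculus), read by resazurin assay, with stated times of 30 min and 2.5 days, in the presence of a further agent that is not named here; a higher number here means a weaker inhibitor, a lower number a stronger inhibitor. Compound 1 and compound 2 share the same core and the same dichlorophenyl amide end, but differ in the length of the chain that joins them and in the group on the triazole nitrogen. The gap between their two numbers lies within the usual scatter of this assay, so the two cannot be told apart on these data, and neither can be called the stronger inhibitor.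

Compound 3 `Cn1nc(Cc2nnc(SCCCCCCCC(=O)Nc3ccc(Cl)cc3Cl)[nH]2)c2ccccc2c1=O` is the next compound to be measured. It differs from compound 1 in one place: hydrogen in place of methyl on an aromatic nitrogen, in words, hydrogen in place of methyl on an aromatic nitrogen. Among the measured compounds shown here, no pair of measured compounds shows this exact change, so its direction cannot be read from the data. For the measured compounds named here, with only a single small group removed and everything else kept, the expected step from compound 1 to compound 3 is a 1.0-fold higher number from compound 1 to compound 3 (0.01 log units; within the scatter), no larger than the scatter. Compound 3 is therefore estimated at 4000 nM, with a range from 1500 nM to 11000 nM.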

Compound 3, half-maximal inhibitory concentration: 3500 nM
For compound 3 the middle estimate is 1.1-fold (0.06 log units) above the measured one; measured number inside the range.
By their numbers in this assay, from the lowest: compounds 3, 1 and 2 (each within the scatter of the next).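

In this assay, among the compounds shown here, replacing the methyl on the aromatic nitrogen with hydrogen, while leaving the rest of the molecule unchanged, gives the first direct reading of this position (a 1.1-fold lower number from compound 1 to compound 3 (0.05 log units; within the scatter)). This places compound 1 and compound 3 within the scatter of each other, so taking away this single carbon leaves no readable mark on the number, and this methyl is not shown to be needed for the inhibition seen with the chain and the dichlorophenyl amide end that these two compounds share. Nothing measured here gives a reason for this result, whether it comes from the methyl itself or from anything else about the two compounds.

The compounds shown leave open what would happen if an ethyl group, a benzyl group or a chain ending in an amine stood on this same nitrogen, since only methyl and hydrogen can be compared directly. They also leave open whether replacing methyl with hydrogen would read the same way with a different chain joining the triazole to the amide end, as this single step comes from only one chain.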